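The source may hold more compounds than are shown below. What is called first, only, known or untested is meant among the compounds shown, and "the series" means these compounds.

Measured compounds:
compound 1, `Cc1cc(Nc2ccn(Cc3cccc4ccccc34)n2)n2nc(SCc3ccc(Br)cc3)nc2n1`, 5660 nM
compound 2, `Cc1cc(Nc2ccn(Cc3ccc(C(F)(F)F)cc3)n2)n2nc(SCc3ccc(Br)cc3)nc2n1`, 5580 nM
compound 3, `Cc1cc(Nc2ccn(Cc3ccc(F)cc3)n2)n2nc(SCc3ccc(Br)cc3)nc2n1`, 19400 nM

All three numbers come from a functional assay on PC-9 cells (Homo sapiens) for inhibition, read by MTT assay, with a stated time of 72 h; on this read-out lower numbers stand for stronger inhibition and higher numbers for weaker inhibition. Compound 3 gives the highest of the three numbers: a 3.4-fold higher number from compound 1 to compound 3 (0.53 log units; beyond the scatter) and a 3.5-fold higher number from compound 2 to compound 3 (0.54 log units; beyond the scatter), both beyond the scatter, while a 1.0-fold lower number from compound 1 to compound 2 (0.01 log units; within the scatter) stays within it. Compound 1 and compound 2 therefore cannot be ordered against each other on these data.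

Compound 4, `Cc1cc(Nc2ccn(Cc3csc4ccc(Cl)cc34)n2)n2nc(SCc3ccc(Br)cc3)nc2n1`, has not yet been measured in this assay. It differs from compound 3 by 5-chloro-1-benzothiophen-3-yl in place of 4-fluorophenyl on a saturated chain carbon bound to an aromatic nitrogen. Within the data shown here, the step that bears most directly on this change is the one from compound 1 to compound 3, where naphthalen-1-yl gave way to 4-fluorophenyl and the number rose modestly. Compound 4 brings back a two-ring aromatic group of about the same size in that position, so the change is read as roughly the reverse of that step. A modestly lower number than compound 3 is expected, a 3.2-fold lower number from compound 3 to compound 4 (0.51 log units; beyond the scatter), landing near the values of compound 1 and compound 2. Compound 4 is thus estimated at 6000 nM, with a range of 2500 nM to 15000 nM.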

Compound 4, half-maximal inhibitory concentration: 4350 nM
Compound 4: middle estimate off by 1.4-fold (0.14 log units), on the high side; the range from low to high includes it.
By their numbers in this assay, from the lowest: compounds 4, 2 and 1 (each within the scatter of the next); then compound 3.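

On a saturated chain carbon bound to an aromatic nitrogen, 5-chloro-1-benzothiophen-3-yl in place of 4-fluorophenyl gives a 4.5-fold lower number from compound 3 to compound 4 (0.65 log units; beyond the scatter) in this assay and so joins naphthalen-1-yl as a second two-ring group that stands clear of compound 3. Against the other groups at this position the change separates nothing, with a 1.3-fold lower number from compound 2 to compound 4 (0.11 log units; within the scatter) and a 1.3-fold lower number from compound 1 to compound 4 (0.11 log units; within the scatter) both inside the scatter, so compound 1, compound 2 and compound 4 form one level that cannot be ordered, and a sulfur-containing ring pair carrying chlorine reads the same there as an all-carbon ring pair. A second ring is not needed to reach that level, since compound 2 goes against any such rule with its single ring bearing trifluoromethyl, and no data are at hand that explain these differences.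

Still open, going by these compounds, is whether the chlorine or the ring sulfur of compound 4 contributes anything, which the plain 1-benzothiophen-3-yl group would test. Also open, on these data alone, is whether this carbon tolerates something other than an aromatic group, such as a piperidine amine, a carboxylic acid or a longer alkyl chain.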